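The source may report more compounds than this note shows. Statements on the series, on what has been measured and on what is new or still open speak of the compounds shown alone.

Measured so far:
compound 1, `Cc1ccccc1N(C)C(=O)c1ccc(-c2ccc(O)cc2)o1`, 21 nM
compound 2, `Cc1ccccc1N(C)C(=O)c1ccc(-c2cccc(O)c2)o1`, 29 nM
compound 3, `Cc1cccc(F)c1N(C)C(=O)c1ccc(-c2ccc(O)cc2)o1`, 120 nM

All three were tested in an assay on T47D cells for inhibition of 17-beta-hydroxysteroid dehydrogenase type 1 (Homo sapiens), read by HPLC, with a stated time of 24 h; a higher number here means a weaker inhibitor, a lower number a stronger inhibitor. Compound 3 gives the highest number of the three, with compound 2 nearest and compound 1 furthest. Compound 4, `Cc1ccc(F)cc1N(C)C(=O)c1ccc(-c2ccc(O)cc2)o1`, differs from compound 3 by 5-fluoro-2-methylphenyl in place of 2-fluoro-6-methylphenyl on an amide-type nitrogen. Within the data shown here, no measured step shifts a fluorine within its ring, so the guide is indirect. The step of a 5.7-fold higher number from compound 1 to compound 3 (0.76 log units; beyond the scatter) shows that adding a fluorine to that ring raised the number, whereas a 1.4-fold higher number from compound 1 to compound 2 (0.14 log units; within the scatter) shows that moving a hydroxyl within its ring changed little. The step of a 2.2-fold lower number from compound 3 to compound 4 (0.34 log units; beyond the scatter) is therefore expected to be modest, more likely toward a lower number than a higher one. Compound 4 is estimated at 55 nM, with a range from 15 nM to 200 nM.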

Compound 4, half-maximal inhibitory concentration: 12 nM
For compound 4 the middle estimate is 4.6-fold (0.66 log units) above the measured one; the whole stated range lies above it.
By their numbers in this assay, from the lowest: compounds 4, 1 and 2 (each within the scatter of the next, the first and the last beyond it); then compound 3.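

The position of the fluorine on the ring carried by the amide-type nitrogen matters: with the same atoms joined differently, the change gives a 10-fold lower number from compound 3 to compound 4 (1.00 log units; beyond the scatter) and undoes the loss seen with compound 3. Adding a fluorine is therefore not harmful in itself, since a 1.8-fold lower number from compound 1 to compound 4 (0.24 log units; within the scatter) in the other fluoro step. Nothing measured here explains why the placement counts.

Still open, going by these compounds, is whether a chlorine or a methoxy group in place of the fluorine in 5-fluoro-2-methylphenyl would give similar numbers.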